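Fluoro in place of methoxy on a sulfanyl phenyl

The compounds below may be only part of what the source reports. "The series", "measured", "known", "first", "only" and "open" are said of these compounds alone.

Of the compounds shown here, two sharing one core have so far been measured in a functional assay on PC-3 cells (Homo sapiens) for inhibition, read by sulforhodamine B assay, with a stated time of 48 h; on this read-out higher numbers stand for lower toxicity in this test and lower numbers for higher toxicity in this test. Compound 1 `COc1cc(CNc2nc3cc(N)cc(N)c3nc2-c2ccccc2)cc(OC)c1OC` returns only a limit, < 50200 nM, which is not a number. For the measured compounds named here, compound 2 `COc1ccc(Sc2nc3cc(N)cc(N)c3nc2-c2ccccc2)cc1` gives 19100 nM, the only full number in this set, the other value being (the limit of < 50200 nM in this assay, at which 1 of the 2 values shown sits). Compound 3 `Nc1cc(N)c2nc(-c3ccccc3)c(Sc3ccc(F)cc3)nc2c1` has not yet been measured and differs from compound 2 by fluoro in place of methoxy on an aromatic carbon. Going by the values given here, no measured pair shows what this swap does here, so the step is expected to be a 1.1-fold lower number from compound 2 to compound 3 (0.05 log units; within the scatter), no further than the usual scatter. Compound 3 is therefore estimated at 17000 nM, within 6000 nM to 50000 nM.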

Compound 3, concentration lethal to 50% of the cells: < 100000 nM
Compound 3: no number, only a limit; the forecaster's own chance of this, stated with the estimate: 15%; the middle value is on the limit's open side.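

For the compounds shown here, compound 3 gives only a limit, not a number, so no step from compound 2 to compound 3 can be read: the limit of < 100000 nM in this assay, at which 1 of the 3 values shown sits. Going by these compounds, how far fluoro in place of methoxy moves the read-out remains open.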